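The compounds below may be only part of what the source reports. "The series", "measured", "known", "first", "only" and "open" are said of these compounds alone.

Compound 1 `COc1cc2sn(CCCCN(C)Cc3ccccc3)c(=O)c2cc1OC` gives 8900 nM in an assay on isolated protein for inhibition of Amine oxidase [flavin-containing] A (Homo sapiens), read by fluorescence, with a stated time of 30 min; a higher number here means a weaker inhibitor, a lower number a stronger inhibitor.
Compound 2 `CCN(CCCCn1sc2cc(OC)c(OC)cc2c1=O)Cc1ccccc1` gives 19900 nM in this assay.
Compound 3 `COc1ccccc1CN(C)CCCCCCn1sc2cc(OC)c(OC)cc2c1=O` gives 19900 nM in this assay.

Of the compounds shown here, three sharing a common core have been measured in this assay. Compound 1 is the lowest of the three numbers. Going from compound 1 to compound 2, the change is methyl in place of hydrogen on a saturated chain carbon bound to an amine nitrogen, and the result is a 2.2-fold higher number from compound 1 to compound 2 (0.35 log units; beyond the scatter). Compound 3 stands level with compound 2 at the digits reported, so the two are within the scatter of each other, while compound 1 sits a modest step below both. The difference between the core of compound 1 and the core of compound 3 is not broken down here; they differ in more than one place.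

Compound 4 `CCN(CCCCCCn1sc2cc(OC)c(OC)cc2c1=O)Cc1ccccc1OC` has not yet been measured in this assay. It differs from compound 3 by methyl in place of hydrogen on a saturated chain carbon bound to an amine nitrogen, the same change as that from compound 1 to compound 2, occurring at the same place: on a saturated chain carbon bound to an amine nitrogen. Because a 2.2-fold higher number from compound 1 to compound 2 (0.35 log units; beyond the scatter) was modest but beyond the scatter, the step from compound 3 to compound 4 is expected to be of similar direction and size, about a 1.8-fold higher number from compound 3 to compound 4 (0.25 log units; within the scatter). On that basis compound 4 is estimated to give roughly 35000 nM in this assay, most likely lying between 15000 nM and 80000 nM. This expectation rests on a single earlier step on a different core, so it is held loosely.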

Compound 4, half-maximal inhibitory concentration: 7900 nM
The estimate for compound 4 lay 4.4-fold (0.65 log units) above the measured number, and the stated range ends above it.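

In this assay, the same change, methyl in place of hydrogen on a saturated chain carbon bound to an amine nitrogen, gives a 2.5-fold lower number from compound 3 to compound 4 (0.40 log units; beyond the scatter), which runs opposite to the step seen earlier on the other core, and the two steps differ in direction and by more than their scatter: the same change on two cores in this assay, a 2.2-fold higher number (0.35 log units; beyond the scatter) from compound 1 to compound 2 and a 2.5-fold lower number (0.40 log units; beyond the scatter) from compound 3 to compound 4, 5.6-fold (0.75 log units) apart, beyond the scatter of two such steps
In this series, then, the change cannot be carried from one core to another as a fixed step, and even its direction did not carry across this one pair of cores, although both steps are modest in size. This does not show which of the differences between the two cores goes with the reversal, since those cores differ in more than one place, and two pairs of compounds give no rule for any further core.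

The compounds shown leave open whether a propyl group on the same amine nitrogen would extend either trend, or whether the step would turn the same way on each core. They also leave open how the same change would behave with an intermediate or longer chain joining the amine nitrogen to the shared core, which could help tell the two steps apart.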